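This account rests on a few compounds, and the source may have more. Where it says the series, first, only, none or still open, it means among the compounds named here.

In an ADME assay on HepG2 cells (Homo sapiens) for cytotoxicity, read by MTT assay, with a stated time of 48 h (a higher number here means a weaker inhibitor, a lower number a stronger inhibitor), compound 1 (`O=S(=O)(c1ccc(-c2ccc3ncnc(Nc4ccc(OCc5cccc(F)c5)c(Cl)c4)c3c2)cc1)N1CCCCC1`) gives > 15000 nM, which is a limit of the assay and not a number. In this assay compound 2 (`O=S(=O)(c1cccc(-c2ccc3ncnc(Nc4ccc(OCc5cccc(F)c5)c(Cl)c4)c3c2)c1)N1CCCC1`) gives > 15000 nM, which is also only a limit. Compound 2 therefore has no numerical value to stand on, and it shares its place with compound 1 at the limit of > 15000 nM in this assay, at which 2 of the 2 values shown sit.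

The next compound, compound 3 (`O=C(c1cccc(-c2ccc3ncnc(Nc4ccc(OCc5cccc(F)c5)c(Cl)c4)c3c2)c1)N1CCCCC1`), keeps the shared core and changes one group: (piperidin-1-yl)carbonyl in place of (pyrrolidin-1-yl)sulfonyl on an aromatic carbon. The new (piperidin-1-yl)carbonyl sits on the same aromatic carbon, meta to a large group, where (pyrrolidin-1-yl)sulfonyl stood in compound 2.

Among the compounds with values here, no measured step sizes this exchange. The expectation rests only on compound 1 and compound 2, which both sit at the limit of > 15000 nM in this assay, at which 2 of the 2 values shown sit. No shift beyond the scatter is expected, and no direction can be favoured, so the estimated a number no higher from compound 2 to compound 3 (the limit leaves the size open) is treated as small. A report of a limit alone is the more likely outcome. For compound 3 the estimated value is 15000 nM, with an expected range of 7000 nM to 30000 nM.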

Compound 3, half-maximal inhibitory concentration: > 6000 nM
Compound 3: a limit, no number (the forecaster's own chance of this, stated with the estimate: 65%); the middle value lies beyond the limit too.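

In this assay compound 3 gives > 6000 nM, which is a limit and not a number. Compound 2 gives > 15000 nM, also only a limit, so the step between compound 2 and compound 3 cannot be read. The compounds shown leave open whether (piperidin-1-yl)carbonyl in place of (pyrrolidin-1-yl)sulfonyl shifts the half-maximal inhibitory concentration at all, and in which direction.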